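The source may report more compounds than this note shows. Statements on the series, on what has been measured and on what is new or still open speak of the compounds shown alone.

Working notes on the series. The shared core of compound 1 `Nc1cc(N)c2nc(-c3ccccc3)c(Oc3ccc(Cl)c(Cl)c3)nc2c1` carries two amino groups and a phenyl ring; in a functional assay on TK-10 cells (Homo sapiens) for inhibition, read by sulforhodamine B assay, with a stated time of 48 h (a lower number here means a stronger inhibitor of growth, a higher number a weaker inhibitor of growth), compound 1 gives 24500 nM. Compound 2 `COc1ccc(CNc2nc3cc(N)cc(N)c3nc2-c2ccccc2)cc1OC` replaces the dichlorophenoxy group with a benzylamino group bearing two methoxy groups; in this assay compound 2 gives 16600 nM. Compound 3 `COc1cc(CNc2nc3cc(N)cc(N)c3nc2-c2ccccc2)cc(OC)c1OC` carries a third methoxy group on that benzyl ring; in this assay compound 3 gives 6310 nM. Among the three numbers, compound 2 stands second highest: it sits within the scatter of compound 1 and is separated from compound 3 by a 2.6-fold lower number from compound 2 to compound 3 (0.42 log units; beyond the scatter).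

Compound 4 `COc1ccc(CNc2nc3cc(N)cc(N)c3nc2-c2ccccc2)cc1` is the next member to be read. It differs from compound 2 by hydrogen in place of methoxy on an aromatic carbon; the same difference, cut one bond further out, reads 3,4-dimethoxyphenyl to 4-methoxyphenyl. For the measured compounds named here, the one measured step that bears on this is the addition of a methoxy from compound 2 to compound 3, which moved the number by a 2.6-fold lower number from compound 2 to compound 3 (0.42 log units; beyond the scatter). Removing a methoxy from the same ring is taken to run the other way, so a modest rise in the number, close to the edge of the scatter, is expected from compound 2 to compound 4: a 1.3-fold higher number from compound 2 to compound 4 (0.12 log units; within the scatter). On that basis compound 4 is estimated at 22000 nM in this assay, with a range from 9000 nM to 55000 nM.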

Compound 4, concentration for 50% growth inhibition: 28200 nM
Compound 4: the middle estimate sits 1.3-fold (0.11 log units) below what was measured; measured number inside the range.
By their numbers in this assay, from the lowest: compound 3; then compounds 2, 1 and 4 (each within the scatter of the next).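

Hydrogen in place of methoxy on this aromatic carbon, ortho to a methoxy group and meta to a large group, reads as a 1.7-fold higher number from compound 2 to compound 4 (0.23 log units; within the scatter) in this assay, so 3,4-dimethoxyphenyl and 4-methoxyphenyl cannot be told apart by this read-out. The series therefore now holds two single methoxy steps on the benzyl ring with different outcomes: a 2.6-fold lower number from compound 2 to compound 3 (0.42 log units; beyond the scatter) lies beyond the scatter, while the step at this position does not, so a methoxy change on this ring does not by itself carry a step beyond the scatter. No measurement is available that bears on what lies behind this result.

The compounds shown leave open whether this position tolerates anything other than methoxy or hydrogen without a step beyond the scatter, for instance a hydroxy group, a chlorine atom or a dimethylamino group. They also leave open how the 4-methoxy group on the same ring reads on its own, as a benzyl ring carrying only hydrogen or a fluorine atom there would be needed for that single-place comparison.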